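A few compounds are considered here, and "the series" means these few. Any claim that something is new, unique, unknown or untested is made for them only; others in the source may bear on it.

Measured so far:

Compound 1, `CCOc1ccc(F)cc1C(C)NC(=O)N(C)S(=O)(=O)c1ccc(Cl)cc1`: in a functional assay on thoracic aorta (Rattus norvegicus, strain Wistar), with a stated time of 15 min (on this read-out higher numbers stand for an effect only at larger amounts of compound and lower numbers for an effect already at smaller amounts), compound 1 gives 24500 nM.
Compound 2, `CCOc1ccc(Cl)cc1C(C)NC(=O)N(C)S(=O)(=O)c1ccc(Cl)cc1`: in this assay compound 2 gives 14600 nM.
Compound 3, `COc1ccc(F)cc1C(C)NC(=O)NS(=O)(=O)c1ccc(C)cc1`: in this assay compound 3 gives only > 300000 nM, which is a limit of the assay and not a number.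

Compound 1 and compound 2 share one core and differ in a single place: chloro in place of fluoro on an aromatic carbon. The step from this change is a 1.7-fold lower number from compound 1 to compound 2 (0.22 log units; within the scatter), so the two values stand within the usual scatter of each other and no order between them is read here.

Compound 3 carries a different core; how the core of compound 1 and the core of compound 3 differ is not broken down here.

Compound 4, `COc1ccc(Cl)cc1C(C)NC(=O)NS(=O)(=O)c1ccc(C)cc1`, has not yet been measured. It differs from compound 3 by chloro in place of fluoro on an aromatic carbon. Going by the values given here, the change is of the same kind as the one from compound 1 to compound 2, not the same: in compound 2 the aromatic carbon concerned is para to an ethoxy group, in compound 4 it is para to a methoxy group.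

For compound 4 in this assay the starting point is only a limit, (the limit of > 300000 nM in this assay, at which 1 of the 3 values shown sits), so no numeric step can be read from compound 3. Among the compounds with values here, the only measured instance of this kind of change, a 1.7-fold lower number from compound 1 to compound 2 (0.22 log units; within the scatter), lies within the scatter. The step from compound 3 to compound 4 is therefore expected to be small, an at least 1.2-fold lower number from compound 3 to compound 4 (0.07 log units; that floor lies within the scatter), and the result for compound 4 is expected to sit at or near the limit again. Compound 4 is thus estimated at 250000 nM, with an expected range from 60000 nM to 1000000 nM.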

Compound 4, half-maximal effective concentration: > 300000 nM
Compound 4 ended at the assay's limit; the forecaster's own chance of this, stated with the estimate: 60%; at least 1.2-fold (0.07 log units) between middle value and limit.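

Compound 3 and compound 4 both end at a limit of this assay, not at a number, so no step can be read between them: the limit of > 300000 nM in this assay, at which 2 of the 4 values shown sit.

The compounds shown leave open whether chloro in place of fluoro shifts the read-out at all on the core of compound 3, where both results are limits, and how that core compares with the core of compound 1.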